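The source may report more compounds than this note shows. Statements on the series, on what has been measured and on what is new or still open speak of the compounds shown alone.

Measured so far in a functional assay on DU-145 cells (Homo sapiens) for inhibition, read by trypan blue exclusion, with a stated time of 96 h; a higher number here means a weaker inhibitor of growth, a lower number a stronger inhibitor of growth:
compound 1, `Cc1ccc(S/C(=C/c2ccc(Cl)c(Cl)c2)C(=O)c2ccc(Br)cc2)cc1`, gives 50000 nM.
compound 2, `Cc1ccc(S/C(=C/c2ccc(F)cc2F)C(=O)c2ccc(Br)cc2)cc1`, gives > 100000 nM.
compound 3, `Cc1ccc(S/C(=C/c2ccc(N(C)C)cc2)C(=O)c2ccc(Br)cc2)cc1`, gives > 100000 nM.

The value of compound 2 is a limit of this assay, not a number. The value of compound 3 is likewise only a limit, so compound 3 stands at the limit of > 100000 nM in this assay, at which 2 of the 3 values shown sit, rather than at a number. Compound 4, `Cc1ccc(S/C(=C/c2ccc(F)c(C)c2)C(=O)c2ccc(Br)cc2)cc1`, differs from compound 3 by 4-fluoro-3-methylphenyl in place of 4-(dimethylamino)phenyl on a double-bonded chain carbon bound to a double-bonded chain carbon. The steps bearing on this change are an at least 2.0-fold higher number from compound 1 to compound 3 (0.30 log units; that floor lies within the scatter) and a step that the two limits leave unreadable from compound 2 to compound 3. The entering group is a halogen-bearing aryl, closer to the rings of compound 1 and compound 2 than to the dimethylamino ring of compound 3. The step from compound 3 to compound 4 is therefore expected to be an at least 1.2-fold lower number from compound 3 to compound 4 (0.09 log units; that floor lies within the scatter), landing near the values of compound 1 and compound 2. For compound 4 the estimated value in this assay is 80000 nM, expected between 25000 nM and 250000 nM.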

Compound 4, concentration for 50% growth inhibition: 25000 nM
Estimate against measurement, compound 4: 3.2-fold (0.51 log units) above, within the range that was stated.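

In this assay, for the compounds shown here, 4-fluoro-3-methylphenyl on a double-bonded chain carbon bound to a double-bonded chain carbon gives the first steps beyond the scatter in this set (an at least 4.0-fold lower number from compound 3 to compound 4 (0.60 log units; beyond the scatter)) and (an at least 4.0-fold lower number from compound 2 to compound 4 (0.60 log units; beyond the scatter)). Against 3,4-dichlorophenyl the change stays within the scatter (a 2.0-fold lower number from compound 1 to compound 4 (0.30 log units; within the scatter)), so these two rings are not separated here. The two steps beyond the scatter start from limits and are floors only: the limit of > 100000 nM in this assay, at which 2 of the 4 values shown sit.

Open, from the compounds shown here alone, is how a ring bearing a carboxylic acid or a morpholine would read at this position. Also open, going by these compounds, is whether replacing the 4-bromophenyl on the carbonyl with an unsubstituted phenyl would shift the values.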